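The source may report more compounds than this note shows. Statements on the series, on what has been measured and on what is new or still open speak of the compounds shown alone.

Measured so far:
compound 1 `CC(C)C(=O)OCOC(=O)C1=C(S[C@@H]2CN[C@H](C(=O)Nc3cccc(C(=O)O)c3)C2)[C@H](C)[C@@H]2[C@@H]([C@@H](C)O)C(=O)N12` — > 95%
compound 2 `C[C@@H](O)[C@H]1C(=O)N2C(C(=O)OCOC(=O)OC(C)(C)C)=C(S[C@@H]3CN[C@H](C(=O)Nc4cccc(C(=O)O)c4)C3)[C@H](C)[C@H]12` — > 95%
compound 3 `C[C@@H](O)[C@H]1C(=O)N2C(C(=O)OCOC(=O)OC3CCCCC3)=C(S[C@@H]3CN[C@H](C(=O)Nc4cccc(C(=O)O)c4)C3)[C@H](C)[C@H]12` — > 95%

In a physicochemical assay for metabolic stability, read by LC-MS, in phosphate buffer, with a stated time of 3 h, at pH 7.4, tested at 50 uM (on this read-out lower numbers stand for a less stable compound and higher numbers for a more stable compound), compound 3 gives only a limit, > 95%, not a number. All three measured values sit at the same limit (the limit of > 95% in this assay, at which 3 of the 3 values shown sit), so the steps a step that the two limits leave unreadable from compound 1 to compound 2, a step that the two limits leave unreadable from compound 1 to compound 3 and a step that the two limits leave unreadable from compound 2 to compound 3 cannot be read in size. The next compound, compound 4 `C[C@@H](O)[C@H]1C(=O)N2C(C(=O)OCOC(=O)C3CCCCC3)=C(S[C@@H]3CN[C@H](C(=O)Nc4cccc(C(=O)O)c4)C3)[C@H](C)[C@H]12`, differs from compound 3 by cyclohexyl in place of cyclohexyloxy on a carbonyl carbon. Among the compounds with values here, no measured step bears on this change, and the three steps already in hand give no readable size to lean on. Compound 4 is therefore expected to stay at the limit, with a step that the limit leaves unreadable from compound 3 to compound 4 in this assay. The estimate for compound 4 is 96%, between 85% and 100%.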

Compound 4, percent of the compound remaining: > 95%
Compound 4: a limit, no number (the forecaster's own chance of this, stated with the estimate: 80%); the middle value does not contradict the limit.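

No step among compound 1, compound 2, compound 3 and compound 4 can be read in this assay, since all four values are limits, not numbers: the limit of > 95% in this assay, at which 4 of the 4 values shown sit.

In this assay the size of any difference among these compounds stays open, as does which change on the carbonyl carbon, if any, would bring a compound off the limit.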